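Chloro for methyl across two cores: cytotoxicity notes

The compounds below may be only part of what the source reports. "The series", "measured", "known", "first", "only" and "open" are said of these compounds alone.

Compound 1 `COc1ccc2nc(C)cc(OCC(=O)Nc3ccc(Cl)cc3)c2c1` and compound 2 `COc1ccc2nc(C)cc(OCC(=O)Nc3ccc(C)cc3)c2c1` share one core; compound 3 `COc1ccccc1NC(=O)COc1cc(C)nc2ccc(C)cc12` and compound 4 `COc1ccccc1NC(=O)COc1cc(C)nc2ccc(Cl)cc12` share another, and the difference between the two cores is not broken down here. In an ADME assay on HepG2 cells (Homo sapiens) for cytotoxicity, read by trypan blue exclusion, with a stated time of 48 h, in the presence of a further agent that is not named here (a lower number here means that less compound is tolerated, a higher number that more compound is tolerated), compound 1 gives 71100 nM and compound 2 gives 41500 nM. For compound 3 this assay reports only a limit, > 74000 nM. The change chloro in place of methyl on an aromatic carbon produced a 1.7-fold higher number from compound 2 to compound 1 (0.23 log units; within the scatter). The change from compound 3 to compound 4 is chloro in place of methyl on an aromatic carbon; it is the same kind of change, but the place differs: in the measured pair the carbon is para to a large group on a ring of carbon only, whereas in the new pair it lies on a ring that is part of a fused or bridged system of two rings, meta to a fused ring and para to a fused ring. Compound 4 is expected to stay close to its parent, with an estimated step that the limit leaves unreadable from compound 3 to compound 4, because a 1.7-fold higher number from compound 2 to compound 1 (0.23 log units; within the scatter) stayed within the scatter and because compound 3 sits at the limit of > 74000 nM in this assay, at which 1 of the 3 values shown sits. For compound 4 in this assay the estimate is 80000 nM, expected between 40000 nM and 160000 nM.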

Compound 4, half-maximal cytotoxic concentration: 99200 nM
For compound 4 the middle estimate is 1.2-fold (0.09 log units) below the measured one, and the stated range covers the measured number.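

The step from compound 3 to compound 4 cannot be read, because the value for compound 3 is only a limit: the limit of > 74000 nM in this assay, at which 1 of the 4 values shown sits.

The compounds shown leave open how large the change of chloro in place of methyl is on the ring that is part of a fused or bridged system of two rings.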